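A few compounds are considered here, and "the series" means these few. Any claim that something is new, unique, unknown or untested is made for them only; others in the source may bear on it.

In a functional assay on SW-620 cells (Homo sapiens) for inhibition, read by MTT assay, with a stated time of 72 h (a lower number here means a stronger inhibitor, a higher number a weaker inhibitor), compound 1 `COc1cc(NC(C)CCCNC(=O)Nc2ccc(Br)cc2)c2ncccc2c1` gives 23000 nM and compound 2 `COc1cc(NC(C)CCCNC(=O)Nc2cccc(C(F)(F)F)c2)c2ncccc2c1` gives 22000 nM, so compound 2 stands level with compound 1 within the scatter. Compound 3 `COc1cc(NC(C)CCCNC(=O)Nc2ccc(Cl)cc2)c2ncccc2c1` has 4-chlorophenyl in place of 3-(trifluoromethyl)phenyl on an amide-type nitrogen. Among the compounds with values here, one measured step bears on this change at the same place: a 1.0-fold lower number from compound 1 to compound 2 (0.02 log units; within the scatter) lies within the scatter. No step beyond the scatter is therefore expected in this assay and no direction is favoured, with the expected step being a 1.0-fold higher number from compound 2 to compound 3 (0.02 log units; within the scatter) here. Compound 3 is estimated at 23000 nM, with an expected range of 13000 nM to 40000 nM here.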

Compound 3, half-maximal inhibitory concentration: 28000 nM
Estimate against measurement, compound 3: 1.2-fold (0.09 log units) below; the measured number falls inside the stated range.
By their numbers in this assay, from the lowest: compounds 2, 1 and 3 (each within the scatter of the next).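

With 4-chlorophenyl on the amide-type nitrogen, a 1.3-fold higher number from compound 2 to compound 3 (0.10 log units; within the scatter) is read in this assay, so a third aryl group at this place stays within the scatter. Chloro in place of bromo on an aromatic carbon isolates a single halogen exchange, with a 1.2-fold higher number from compound 1 to compound 3 (0.09 log units; within the scatter) as its result, and this too lies within the scatter. No measurement at hand explains this flat response.

Open, on these data alone, is whether a carboxylic acid or an amine on the aryl ring changes the number beyond the scatter. Also open, as far as these compounds go, is the effect of a longer chain joining the urea carbonyl side to the shared core.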